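Swapping a Dimethoxyphenyl for a Bromophenyl at the Ester End

The source may hold more compounds than are shown below. What is called first, only, known or untested is meant among the compounds shown, and "the series" means these compounds.

Three esters sharing one core have been tested so far. Compound 1 `COc1ccccc1/C=C/C(=O)OC/C=C/c1cc(OC)c(OC)cc1OC`, compound 2 `COc1cc(OC)c(OC)cc1/C=C/COC(=O)/C=C/c1ccc(OC)c(OC)c1` and compound 3 `COc1cc(OC)c(OC)cc1/C=C/COC(=O)/C=C/c1c(OC)ccc(OC)c1OC` were each examined in a functional assay on the whole organism (strain Kunming) with Mus musculus as the target, with a stated time of 0.5 h, at a dose of 100 mg/kg by the intraperitoneal route; on this read-out lower numbers stand for a stronger effect and higher numbers for a weaker effect at the one dose given. In this assay compound 1 gives 100%, compound 2 gives 100% and compound 3 gives 100%. Among the measured compounds shown here, the one single-site step among them, no change at the digits printed from compound 1 to compound 2 (within the scatter), shows that exchanging one methoxy-bearing ring for another left the read-out where it was. Compound 2 thus stands level with compound 1 and compound 3 at the digits shown, and none of the three can be called more or less active than another.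

Compound 4 `COc1cc(OC)c(OC)cc1/C=C/COC(=O)/C=C/c1ccc(Br)cc1` has not been measured. It differs from compound 2 in one place: 4-bromophenyl in place of 3,4-dimethoxyphenyl on a double-bonded chain carbon bound to a double-bonded chain carbon. The 4-bromophenyl enters, and the 3,4-dimethoxyphenyl leaves, on a double-bonded chain carbon bound to a double-bonded chain carbon.

For the measured compounds named here, only the step from compound 1 to compound 2 touches this position, and it was within the scatter, so the expectation for the step from compound 2 to compound 4 is no change beyond the scatter, which is what no change at the digits printed from compound 2 to compound 4 (within the scatter) means here. Compound 4 is therefore expected to give about 100% in this assay, with a likely range from 85% to 100%.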

Compound 4, a percentage reported as activity, at one dose (the size of the read-out at that dose, not a potency): 100%
Compound 4: the middle estimate sits on the measured number at the digits printed; low and high end bracket the measured number.
By their numbers in this assay, from the lowest: compounds 1, 2, 3 and 4 (each within the scatter of the next).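

Replacing the 3,4-dimethoxyphenyl with a 4-bromophenyl gives no change at the digits printed from compound 2 to compound 4 (within the scatter) in this assay and so extends the picture beyond methoxy-bearing rings: a ring with bromine and no oxygen, and with 0 hydrogen-bond acceptors instead of 2, is read the same at this position. The comparison with the 2-methoxyphenyl ring points the same way, with no change at the digits printed from compound 1 to compound 4 (within the scatter) in this assay, so this read-out does not separate any of the three rings that have occupied this position in these single-place comparisons. No independent measurement is available to explain this flat result.

The compounds shown leave open whether any group on this double-bonded chain carbon can lower the number in this assay, since every ring tried so far gives the same printed value. A phenyl ring carrying an amine or a carboxylic acid, or a longer saturated alkyl chain in place of the ring, would test this position with groups quite unlike the methoxy and bromine substituents seen here.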